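Furan in Place of Thiophene: Expecting Compound 4

The source may report more compounds than this note shows. Statements on the series, on what has been measured and on what is new or still open speak of the compounds shown alone.

Of the compounds shown here, three have been measured in an assay on cells for displacement of a labelled ligand from adenosine receptor A1 (Homo sapiens), read by radioligand binding, with a stated time of 60 min, tested at 1 uM; on this read-out lower numbers stand for less inhibition and higher numbers for more inhibition at the one concentration tested (going by the name of the read-out). Compound 1 `CC1=C(C(=O)OC(C(F)(F)F)C(F)(F)F)C(c2ccsc2)NC(=O)N1` gives 17%, compound 2 `CC(C)OC(=O)C1=C(C(F)(F)F)NC(=O)NC1c1ccsc1` gives 23%, and compound 3 `CC1=C(C(=O)OC(C(F)(F)F)C(F)(F)F)C(c2ccoc2)NC(=O)N1` gives 7%. Of the three numbers, that of compound 2 is the highest, though its distance from compound 1 lies within the scatter and only its distance from compound 3 lies beyond it. The unmeasured compound 4 `CC(C)OC(=O)C1=C(C(F)(F)F)NC(=O)NC1c1ccoc1` differs from compound 2 in one place: furan-3-yl in place of thiophen-3-yl on a saturated ring carbon. Going by the values given here, one measured step bears on this change, the same exchange carried out on the core shared by compound 1 and compound 3, which gave a number 10 percentage points lower from compound 1 to compound 3 (within the scatter). On that basis a downward step of similar size, most likely within the scatter, is expected here, so that compound 4 is estimated at 13% with a range from 2% to 25%. The expected step amounts to a number 10 percentage points lower from compound 2 to compound 4 (within the scatter). Among the compounds with values here, no measured pair shows whether the trifluoromethyl and isopropoxycarbonyl groups of compound 2 change this response.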

Compound 4, a percentage reported as inhibition, at one concentration (the size of the read-out at that concentration, not a potency): 27%
Estimate against measurement, compound 4: 14 percentage points below, and the stated range ends below it.
By their numbers in this assay, from the lowest: compounds 3, 1, 2 and 4 (each within the scatter of the next, the first and the last beyond it).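

On the core of compound 2, furan-3-yl in place of thiophen-3-yl on the saturated ring carbon gives a number 4 percentage points higher from compound 2 to compound 4 (within the scatter) in this assay. The change has now been read on two cores, and on neither does it move the number beyond the scatter, so this read-out at the one concentration tested does not separate the two rings at this position. The downward direction seen between compound 1 and compound 3 does not hold as a rule, yet the two steps cannot be told apart either: the same change on two cores in this assay, a number 10 percentage points lower (within the scatter) from compound 1 to compound 3 and a number 4 percentage points higher (within the scatter) from compound 2 to compound 4, 14 percentage points apart, within the scatter of two such steps

Going by these compounds, whether a phenyl ring or a ring carrying an amine at this position would shift the number beyond the scatter remains open. Compound 1 and compound 2 differ in more than one place, so the separate contributions of the trifluoromethyl and isopropoxycarbonyl groups also stay unresolved.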